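Replacing the aromatic amide group in a limit compound

A few compounds are considered here, and "the series" means these few. Any claim that something is new, unique, unknown or untested is made for them only; others in the source may bear on it.

Measured so far:
Compound 1, `O=C(C1CCC(F)(F)CC1)N1CC(c2nc(-c3cccc(Cl)c3)no2)C1`: 180 nM in an assay on HEK293 cells for positive allosteric modulation of metabotropic glutamate receptor 5 (Homo sapiens), read by FLIPR; on this read-out higher numbers stand for an effect only at larger amounts of compound and lower numbers for an effect already at smaller amounts
Compound 2, `O=C([C@H]1CC2CCC1C2)N1CC(c2nc(-c3cccc(F)c3)no2)C1`: 72 nM
Compound 3, `O=C(c1ccccc1F)N1CC(c2nc(-c3cccc(Cl)c3)no2)C1`: > 10000 nM

Compound 3 gives only a limit of this assay, > 10000 nM; no number is known for it, and it stands at the limit of > 10000 nM in this assay, at which 1 of the 3 values shown sits. Compound 1 and compound 2, both carrying a saturated ring on the carbonyl carbon, give numbers far below that limit. Going by the values given here, the one measured step that bears on the change is an at least 55-fold higher number from compound 1 to compound 3 (1.74 log units; beyond the scatter).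

Compound 4, `O=C([C@H]1CC2CCC1C2)N1CC(c2nc(-c3cccc(Cl)c3)no2)C1`, has not been measured. It differs from compound 3 by a group of 7 heavy atoms (7 carbon; 2 five-membered non-aromatic rings of carbon only) in place of a group of 7 heavy atoms (6 carbon, 1 fluorine; one six-membered aromatic ring of carbon only), on a carbonyl carbon. This reverses the kind of change seen in the step from compound 1 to compound 3, so the number is expected to fall again. Compound 2 carries the same bicyclic group and gives 72 nM; compound 1 carries the same chlorophenyl part and gives 180 nM. Compound 4 is therefore estimated at 100 nM, in the range 40 nM to 300 nM, which is expected to mean an at least 100-fold lower number from compound 3 to compound 4 (2.00 log units; beyond the scatter).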

Compound 4, half-maximal effective concentration: 74 nM
Compound 4: middle estimate off by 1.4-fold (0.13 log units), on the high side, within the range that was stated.
By their numbers in this assay, from the lowest: compounds 2 and 4 (each within the scatter of the next); then compound 1. At a limit, above all of these: compound 3.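

Compound 3 remains a limit of this assay, so the size of the change to the bicyclic group can be told from one side only: the limit of > 10000 nM in this assay, at which 1 of the 4 values shown sits. With the chlorophenyl part held fixed, the bicyclic group on the carbonyl carbon brings an at least 130-fold lower number from compound 3 to compound 4 (2.13 log units; beyond the scatter) in place of 2-fluorophenyl, and even among saturated rings this position still tells groups apart, with a 2.4-fold lower number from compound 1 to compound 4 (0.39 log units; beyond the scatter) against the 4,4-difluorocyclohexyl group. Chloro in place of fluoro on the aromatic carbon gives a 1.0-fold higher number from compound 2 to compound 4 (0.01 log units; within the scatter), so with the bicyclic group in place this exchange leaves the two compounds within the scatter.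

As far as these compounds go, whether an open chain such as tert-butyl, or an amine on the saturated ring, would be accepted on the carbonyl carbon stays open. So does whether aromatic groups other than 2-fluorophenyl, such as an unsubstituted phenyl or a pyridine, fall to the same limit.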